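Adding a chloro to compound 2

The source may report more compounds than this note shows. Statements on the series, on what has been measured and on what is new or still open speak of the compounds shown alone.

Measured in an ADME assay on HEK293 cells (Homo sapiens) for cytotoxicity, read by reporter gene assay and resazurin assay, with a stated time of 48 h; on this read-out lower numbers stand for higher toxicity in this test and higher numbers for lower toxicity in this test

Compound 1 `COc1ccccc1C(=O)Nc1ccc(Sc2nc3ccccc3s2)cc1` gives > 100000 nM as a limit of the assay
Compound 2 `O=C(Nc1ccc(Sc2nc3ccccc3s2)cc1)c1ccccc1O` gives 74000 nM
Compound 3 `O=C(Nc1ccc(Sc2nc3ccccc3s2)cc1)c1cccc(Br)c1O` gives 71000 nM

Compound 2 and compound 3 lie within the scatter of each other, so compound 2 stands level with compound 3 on these numbers. The only other result is the limit of compound 1.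

Compound 4 `O=C(Nc1ccc(Sc2nc3ccccc3s2)c(Cl)c1)c1ccccc1O` differs from compound 2 by chloro in place of hydrogen on an aromatic carbon with chloro in place of hydrogen on an aromatic carbon, ortho to a large group and meta to a large group.

The closest measured change, bromo in place of hydrogen on an aromatic carbon, gave a 1.0-fold lower number from compound 2 to compound 3 (0.02 log units; within the scatter) and stayed within the scatter. That bromo sits elsewhere in the molecule, so it is only a partial guide. The step of an at least 1.3-fold lower number from compound 1 to compound 2 (0.13 log units; that floor lies within the scatter) is a change of another kind, hydrogen in place of methyl on an oxygen, and its floor also lies within the scatter.

Going by the step to compound 3 (a 1.0-fold lower number from compound 2 to compound 3 (0.02 log units; within the scatter)), no shift beyond the scatter is expected in this assay in either direction. The estimated change is a 1.2-fold lower number from compound 2 to compound 4 (0.09 log units; within the scatter) and it stays within the scatter. Compound 4 is expected at 60000 nM (expected range 30000 nM to 100000 nM).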

Compound 4, half-maximal cytotoxic concentration: 64000 nM
Compound 4: the middle estimate sits 1.1-fold (0.03 log units) below what was measured, within the range that was stated.
By their numbers in this assay, from the lowest: compounds 4, 3 and 2 (each within the scatter of the next). At a limit, above all of these: compound 1.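

In this assay, the earlier steps touched only the aromatic group on the carbonyl carbon, so compound 4 is the first of these compounds to carry a change elsewhere in the molecule. Chloro in place of hydrogen on this aromatic carbon, ortho to a large group and meta to a large group, gives a 1.2-fold lower number from compound 2 to compound 4 (0.06 log units; within the scatter), so this position takes a chloro with no shift beyond the scatter in this test. Read beside a 1.0-fold lower number from compound 2 to compound 3 (0.02 log units; within the scatter), which is also within the scatter, a single halogen at either of these two places leaves the number without a shift that can be told from the scatter.

Compound 1 offers no number for comparison, only a limit of the assay: the limit of > 100000 nM in this assay, at which 1 of the 4 values shown sits.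

What the compounds shown leave open is whether an amine, a carboxylic acid or a longer chain at the position of the chloro would move the number beyond the scatter, and whether chloro and bromo together in one molecule would stay as level as each does alone.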